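The compounds below may be only part of what the source reports. "The series", "measured", "known", "first", "only" and "open" are said of these compounds alone.

Measured in an ADME assay on a cell-free system (plasma, Mus musculus) for metabolic stability, read by LC-MS, tested at 2 uM; on this read-out higher numbers stand for a longer-lived compound and lower numbers for a shorter-lived compound:
- Compound 1 `O=C(NCCCCc1ccccc1)n1cc(-c2ccc(F)cc2)oc1=O`: 1.5 h
- Compound 2 `COc1cc(-c2cn(C(=O)NCCCCc3ccccc3)c(=O)o2)ccc1F`: > 2 h (a limit of the assay, not a number)
- Compound 3 `O=C(NCCCCc1ccccc1)n1cc(-c2cccnc2)oc1=O`: 1 h

In this assay, among the compounds with values here, compound 3 stands at 1 h, within the scatter of compound 1, the only other compound with a plain number. Compound 4 `O=C(NCCCCc1ccccc1)n1cc(-c2ccncc2)oc1=O` differs from compound 3 in one place, with the same atoms joined differently: pyridin-4-yl in place of pyridin-3-yl on an aromatic carbon. Within the data shown here, no measured step makes this exact change. The nearest evidence comes from the steps that introduced pyridin-3-yl at the same aromatic carbon. Replacing 4-fluorophenyl gave a 1.5-fold lower number from compound 1 to compound 3 (0.18 log units; within the scatter). Replacing 4-fluoro-3-methoxyphenyl gave an at least 2.0-fold lower number from compound 2 to compound 3 (0.30 log units; that floor lies within the scatter). Neither shows a shift beyond the scatter, even though those changes of group are larger than the one at hand. No step beyond the scatter is therefore expected for pyridin-4-yl in place of pyridin-3-yl, and no direction can be favoured. The estimated step is no change at the digits printed from compound 3 to compound 4 (within the scatter). For compound 4 the expected half-life is estimated at 1 h, with an estimated range of 0.5 h to 2 h.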

Compound 4, half-life: 0.5 h
Estimate against measurement, compound 4: 2.0-fold (0.30 log units) above; low and high end bracket the measured number.
By their numbers in this assay, from the lowest: compounds 4, 3 and 1 (each within the scatter of the next, the first and the last beyond it). At a limit, above all of these: compound 2.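

In this assay, within the data shown here, the swap of pyridin-3-yl for pyridin-4-yl on the aromatic carbon next to the ring oxygen gives a 2.0-fold lower number from compound 3 to compound 4 (0.30 log units; within the scatter), yet pyridin-4-yl in place of 4-fluorophenyl gives a 3.0-fold lower number from compound 1 to compound 4 (0.48 log units; beyond the scatter), the first step at this position between two plain numbers to lie beyond the scatter. Pyridin-4-yl in place of 4-fluoro-3-methoxyphenyl gives an at least 4.0-fold lower number from compound 2 to compound 4 (0.60 log units; beyond the scatter), so both steps from the phenyl groups to pyridin-4-yl now clear the scatter, while neither step to pyridin-3-yl did. Compound 2 stands at a limit, so its step is only a floor: the limit of > 2 h in this assay, at which 1 of the 4 values shown sits.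

The compounds shown leave open whether pyridin-2-yl, or a pyridin-4-yl carrying a fluorine or a methoxy group, would fall with the pyridine compounds or with the phenyl compounds. They also leave open whether the same order would hold with a shorter chain in place of the phenyl-bearing chain.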